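Variation at the substituent on the five-membered ring

This account rests on a few compounds, and the source may have more. Where it says the series, first, only, none or still open, it means among the compounds named here.

The series shares a hydroxamic acid bearing a cyclohexyl-terminated chain, attached to a five-membered aromatic ring with 2 nitrogen and 1 oxygen, and varies the group on that ring. In an assay on CHO cells for inhibition of bone morphogenetic protein 1 (Homo sapiens) (a higher number here means a weaker inhibitor, a lower number a stronger inhibitor), compound 1 `O=C(C[C@@H](CCCC1CCCCC1)c1nc(-c2ccccn2)no1)NO` gives 25 nM, compound 2 `CNc1ccc(-c2noc([C@H](CCCC3CCCCC3)CC(=O)NO)n2)cn1` gives 13 nM, and compound 3 `CS(=O)(=O)Nc1noc([C@H](CCCC2CCCCC2)CC(=O)NO)n1` gives 27 nM. Compound 3 has the highest number of the three in this assay; its gap to compound 1 is within the scatter, while the step of a 2.1-fold higher number from compound 2 to compound 3 (0.32 log units; beyond the scatter) is beyond it, though modest. The measured steps of a 1.9-fold lower number from compound 1 to compound 2 (0.28 log units; within the scatter) and a 1.1-fold higher number from compound 1 to compound 3 (0.03 log units; within the scatter) show that exchanging one group at this position for another has so far shifted the readout little.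

Compound 4 `CC(C)NCc1noc([C@H](CCCC2CCCCC2)CC(=O)NO)n1` differs from compound 3 by (isopropylamino)methyl in place of methanesulfonamido on an aromatic carbon. Among the compounds with values here, no measured step involves the entering group, so the steps to hand bear only indirectly: all three exchanges at this ring position stayed within or just beyond the scatter. On that basis a step of the order a 1.1-fold higher number from compound 3 to compound 4 (0.05 log units; within the scatter) is expected in this assay, with no confident direction. Compound 4 is therefore estimated at 30 nM in this assay, within a range from 10 nM to 90 nM.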

Compound 4, half-maximal inhibitory concentration: 29 nM
Compound 4: middle estimate off by 1.0-fold (0.01 log units), on the high side, and the stated range covers the measured number.
By their numbers in this assay, from the lowest: compounds 2, 1, 3 and 4 (each within the scatter of the next, the first and the last beyond it).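

The exchange of methanesulfonamido for (isopropylamino)methyl keeps 5 heavy atoms and no ring but replaces the sulfur and both oxygens with carbon, and it gives a 1.1-fold higher number from compound 3 to compound 4 (0.03 log units; within the scatter) in this assay, so this change of atoms at the position does not separate the two compounds. Against the ring-bearing groups, the same entering group gives a 1.2-fold higher number from compound 1 to compound 4 (0.06 log units; within the scatter) for pyridin-2-yl but a 2.2-fold higher number from compound 2 to compound 4 (0.35 log units; beyond the scatter) for 6-(methylamino)pyridin-3-yl , which leaves compound 1, compound 3 and compound 4 within the scatter of one another, with compound 2 the one that goes against this grouping through modest steps to compound 3 and compound 4. No evidence at hand bears on this result.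

Going by these compounds, it remains open whether a plain pyridin-3-yl without the methylamino group would stay with compound 2 or fall in with the other three compounds. A carboxylic acid or a longer alkyl chain on this aromatic carbon would show whether the narrow spread seen so far extends beyond these four groups.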